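The source may hold more compounds than are shown below. What is called first, only, known or untested is meant among the compounds shown, and "the series" means these compounds.

Working notes on the diamino core series in a functional assay on HCT-15 cells (Homo sapiens) for inhibition, read by sulforhodamine B assay, with a stated time of 48 h; a higher number here means a weaker inhibitor of growth, a lower number a stronger inhibitor of growth.

Of the compounds shown here, two carry a number so far. Compound 1 `Nc1cc(N)c2nc(-c3ccccc3)c(Oc3ccc(Cl)c(Cl)c3)nc2c1` gives 20000 nM in this assay. Compound 2 `CCOC(=O)[C@H](CCC(=O)O)NC(=O)c1ccc(Sc2nc3cc(N)cc(N)c3nc2-c2ccccc2)cc1` gives 13500 nM in this assay. Of the two numbers, compound 1 has the higher one, but the gap to compound 2 is within the usual scatter of repeat measurements, so the two compounds are not separated by these data. Going by the values given here, the two compounds differ in more than one place, so no single step between them can be read off.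

The next compound, compound 3 `Nc1cc(N)c2nc(-c3ccccc3)c(Sc3ccc(F)cc3)nc2c1`, differs from compound 1 in one place: (4-fluorophenyl)sulfanyl in place of 3,4-dichlorophenoxy on an aromatic carbon. Compound 1 carries an aryl ether at the same position of the shared core, and compound 2 an aryl thioether; compound 2 already sits in the same range, at 13500 nM. For compound 3 the change is therefore expected to give a step from compound 1 that stays within the scatter, or at most a small drop in the number, as a 1.7-fold lower number from compound 1 to compound 3 (0.22 log units; within the scatter). The estimate for compound 3 is 12000 nM, with a range from 4000 nM to 40000 nM.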

Compound 3, concentration for 50% growth inhibition: 13500 nM
Compound 3: middle estimate off by 1.1-fold (0.05 log units), on the low side, and the stated range covers the measured number.
By their numbers in this assay, from the lowest: compounds 2, 3 and 1 (each within the scatter of the next).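

In this assay, going by these compounds alone, the exchange at this aromatic carbon, next to the ring nitrogen and ortho to the phenyl group, gives a 1.5-fold lower number from compound 1 to compound 3 (0.17 log units; within the scatter), the first step that can be read. The step replaces 3,4-dichlorophenoxy with (4-fluorophenyl)sulfanyl, changing the linking atom and the halogen pattern on the outer aromatic ring together, and this combined change does not separate the two compounds. No supporting data bear on this result, so it stands as an observation on one pair of compounds.

As far as these compounds go, the effect of each part of the change alone remains open, as a single step cannot show whether the linking atom and the halogens each leave the number within the scatter or whether their contributions offset each other. Also open, from the compounds shown here alone, is how the number responds at this same aromatic carbon to an amine as the linking group, or to a carboxylic acid on the outer aromatic ring.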